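The source may report more compounds than this note shows. Statements on the series, on what has been measured and on what is new or still open speak of the compounds shown alone.

Measured so far:
compound 1 `N/C(=N\NC(=S)N1CCN(c2ccccn2)CC1)c1ccc(F)cn1` — 13400 nM
compound 2 `N/C(=N\NC(=S)N1CCCC1)c1ccc(F)cn1` — 1000 nM
compound 3 `Cc1ccnc(/C(N)=N/NC(=S)N2CCSCC2)c1` — 7200 nM

In a functional assay on A-431 cells (Homo sapiens) for cytotoxicity, read by MTT assay, with a stated time of 72 h (a lower number here means a stronger inhibitor, a higher number a weaker inhibitor), compound 2 gives the lowest number of the three; compound 3 stands a large distance above it and compound 1 further still, both gaps beyond the scatter. Compound 4 `N/C(=N\NC(=S)N1CCSCC1)c1ccc(F)cn1` is compound 2 with thiomorpholin-4-yl in place of pyrrolidin-1-yl on a thiocarbonyl carbon. Within the data shown here, no step with exactly this change has been measured; the only thiomorpholin-4-yl compound, compound 3, sits on a different core, so it offers at best a hint. The author expects the step from compound 2 to compound 4 to move the number up, a 4.0-fold higher number from compound 2 to compound 4 (0.60 log units; beyond the scatter), beyond the scatter but short of the gap to compound 3. The estimate for compound 4 is 4000 nM, with a range from 1500 nM to 12000 nM.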

Compound 4, half-maximal inhibitory concentration: 1200 nM
Compound 4: the middle estimate sits 3.3-fold (0.52 log units) above what was measured, outside the stated range (below it).
By their numbers in this assay, from the lowest: compounds 2 and 4 (each within the scatter of the next); then compounds 3 and 1 (each within the scatter of the next).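

With the core held fixed, thiomorpholin-4-yl in place of pyrrolidin-1-yl on a thiocarbonyl carbon gives a 1.2-fold higher number from compound 2 to compound 4 (0.08 log units; within the scatter) in this assay, so this change leaves the number level at this position. The position does not accept every group alike, however: compound 1, on the same core, gives 13400 nM. Nothing available explains why the two rings read alike. On these data alone, it remains open whether a morpholine, a piperidine or an open-chain dimethylamine at this position would also stay level with compound 2.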